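This account rests on a few compounds, and the source may have more. Where it says the series, first, only, none or still open, it means among the compounds named here.

Compound 1, with the structure `COc1ccccc1N1CCN(CCCCn2ncc(N3CCN(C(=O)c4ccco4)CC3)c(Cl)c2=O)CC1`, is the starting point. In an assay on cell membranes for binding affinity to Adrenergic receptor alpha-1 (Rattus norvegicus), read by radioligand binding (on this read-out lower numbers stand for stronger inhibition and higher numbers for weaker inhibition), compound 1 gives 33.5 nM. Compound 2, drawn as `O=C(c1ccco1)N1CCN(c2cnn(CCCCN3CCN(c4ccccc4Cl)CC3)c(=O)c2Cl)CC1`, carries one change relative to compound 1: chloro in place of methoxy on an aromatic carbon. In this assay compound 2 gives 19 nM, and the step is a 1.8-fold lower number from compound 1 to compound 2 (0.25 log units; within the scatter). Within this pair, then, swapping the methoxy group for a chloro group moved the number by an amount that repeated measurements could produce on their own.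

Compound 3, with the structure `COc1ccccc1N1CCN(CCCCCCn2ncc(N3CCN(C(=O)c4ccco4)CC3)c(Cl)c2=O)CC1`, shares the methoxy-bearing end of compound 1 but has a different core; how the two cores differ is not broken down here. In this assay compound 3 gives 4.1 nM, the lowest number among the three measured compounds, and its gap to compound 2 as well as to compound 1 is larger than the usual scatter.

Compound 4, drawn as `O=C(c1ccco1)N1CCN(c2cnn(CCCCCCN3CCN(c4ccccc4Cl)CC3)c(=O)c2Cl)CC1`, has not yet been measured. It stands to compound 3 as compound 2 stands to compound 1: chloro in place of methoxy on an aromatic carbon. The surroundings of the change are described in the same words for both pairs, so this is the same change made on a second core. For compound 4 the expected step is a 1.6-fold lower number from compound 3 to compound 4 (0.21 log units; within the scatter), resting on the fact that the same change from compound 1 to compound 2 gave a 1.8-fold lower number from compound 1 to compound 2 (0.25 log units; within the scatter). Compound 4 is therefore estimated at 2.5 nM, with a likely range from 1 nM to 6 nM.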

Compound 4, inhibition constant: 5.7 nM
Beside the measured number, compound 4's estimate is 2.3-fold (0.36 log units) below it; the range from low to high includes it.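

In this assay, putting the 2-chlorophenyl group in place of the 2-methoxyphenyl group on the second core gives a 1.4-fold higher number from compound 3 to compound 4 (0.14 log units; within the scatter), so on neither core does this swap move the number by more than repeated measurements could produce on their own. The two steps are printed with opposite directions, but that contrast is not a real difference between the cores: the same change on two cores in this assay, a 1.8-fold lower number (0.25 log units; within the scatter) from compound 1 to compound 2 and a 1.4-fold higher number (0.14 log units; within the scatter) from compound 3 to compound 4, 2.5-fold (0.39 log units) apart, within the scatter of two such steps. This shows that, across these two pairs, the swap behaved the same on both cores as far as this measurement can tell, with no sign that the core changes its outcome; it does not show that the two groups are truly equal, that the swap would stay this small on any further core, or why the numbers fall where they do.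

The compounds shown leave open how other groups would read in the same place on the aromatic ring, such as a fluoro group, a methyl group or a trifluoromethyl group. They also leave open whether the methoxy-to-chloro swap would stay within the scatter on a core carrying a longer chain than those in compound 3 and compound 4.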